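The source may report more compounds than this note shows. Statements on the series, on what has been measured and on what is new or still open speak of the compounds shown alone.

Compound 1, `CC(C)(C)c1cc(-c2cc(=O)c3ccc(OCC(O)CO)cc3o2)cc(C(C)(C)C)c1O`: 100 nM
Compound 2, `CC(C)(C)c1cc(-c2cc(=O)c3ccc(OCCO)cc3o2)cc(C(C)(C)C)c1O`: 3000 nM
Compound 3, `CCOC(=O)C(C)(C)Oc1ccc2c(=O)cc(-c3cc(C(C)(C)C)c(O)c(C(C)(C)C)c3)oc2c1`: 3000 nM

These three compounds share one core and differ only in the chain attached to an oxygen on an aromatic ring. In a functional assay for inhibition (a lower number here means a stronger inhibitor, a higher number a weaker inhibitor), compound 1 gives 100 nM, the lowest of the three numbers. Compound 3 stands at the top together with compound 2: the step of no change at the digits printed from compound 2 to compound 3 (within the scatter), whereas the step of a 30-fold higher number from compound 1 to compound 3 (1.48 log units; beyond the scatter). Compound 4, `CCOC(=O)COc1ccc2c(=O)cc(-c3cc(C(C)(C)C)c(O)c(C(C)(C)C)c3)oc2c1`, is not yet measured. It differs from compound 3 in one place: (ethoxycarbonyl)methyl in place of 1-(ethoxycarbonyl)-1-methylethyl on an oxygen on an aromatic ring. For the measured compounds named here, of the measured steps, the one from compound 2 to compound 3 comes nearest, since it also exchanges the chain on that oxygen for the 1-(ethoxycarbonyl)-1-methylethyl group and brought no change beyond the scatter. Going by the values given here, the large step of a 30-fold higher number from compound 1 to compound 3 (1.48 log units; beyond the scatter) shows that this chain can matter a great deal, but no measured pair shortens the chain in the way compound 4 does, so no direct guide exists. The expectation is therefore a small step, no change at the digits printed from compound 3 to compound 4 (within the scatter), with no settled direction. Compound 4 is expected to give about 3000 nM, within a range from 800 nM to 10000 nM.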

Compound 4, half-maximal inhibitory concentration: 3000 nM
The estimate for compound 4 equals the measured number at the digits printed; low and high end bracket the measured number.
By their numbers in this assay, from the lowest: compound 1; then compounds 2, 3 and 4 (each within the scatter of the next).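

In this assay, putting (ethoxycarbonyl)methyl in place of 1-(ethoxycarbonyl)-1-methylethyl on the oxygen on the aromatic ring gives a clear answer (no change at the digits printed from compound 3 to compound 4 (within the scatter)), so the shorter ester chain and the larger one cannot be told apart in this read-out. Compound 4 also matches the compound carrying the 2-hydroxyethyl chain (no change at the digits printed from compound 2 to compound 4 (within the scatter)), yet it remains well apart from the compound carrying the 2,3-dihydroxypropyl chain (a 30-fold higher number from compound 1 to compound 4 (1.48 log units; beyond the scatter)). Three different chains now share one level, and among these four compounds only compound 1 stands apart, so the stronger inhibition seen here belongs to the 2,3-dihydroxypropyl chain alone and not to the esters or to the 2-hydroxyethyl chain.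

Still open, going by these compounds, is how a carboxylic acid in place of the ethyl ester, an amine on the chain, or a longer chain carrying further hydroxyl groups would compare with compound 1 at 100 nM in this assay. Nothing beyond these assay numbers bears on the result, so the reason for this pattern remains unknown.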